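Furan-3-yl Against Thiophen-2-yl on the Sulfonyl Sulfur

This account rests on a few compounds, and the source may have more. Where it says the series, first, only, none or still open, it means among the compounds named here.

Compound 1, `CNCc1cc(-c2cccnc2F)n(S(=O)(=O)c2cccc(F)c2)c1`: 99%
Compound 2, `CNCc1cc(-c2cccnc2F)n(S(=O)(=O)c2cccs2)c1`: 96%

The two measured compounds share one core and differ only in the group on the sulfonyl sulfur. In a functional assay on the whole organism (strain Jcl:SD) for inhibition, with Rattus norvegicus as the target, with stated times of 3 min and 3 h, at a dose of 1 mg/kg by the intravenous route (on this read-out lower numbers stand for less inhibition and higher numbers for more inhibition at the one dose given (going by the name of the read-out)), compound 1 gives 99%, and compound 2 gives 96%. Going by the values given here, the single measured step is a number 3 percentage points lower from compound 1 to compound 2 (within the scatter), so compound 2 stands alongside compound 1, the two numbers within the scatter of each other. Compound 3, `CNCc1cc(-c2cccnc2F)n(S(=O)(=O)c2ccoc2)c1`, has not been measured. It differs from compound 2 in one place: furan-3-yl in place of thiophen-2-yl on a sulfonyl sulfur. Among the compounds with values here, the only comparison that bears on it is the exchange of the group on the sulfonyl sulfur from compound 1 to compound 2, which stayed within the scatter. No step beyond the scatter is therefore expected in this assay; the expected step is a number 3 percentage points lower from compound 2 to compound 3 (within the scatter). Compound 3 is estimated at 93%, with a range from 78% to 99%.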

Compound 3, a percentage reported as inhibition, in the whole organism at one dose (the size of the read-out at that dose, not a potency): 82%
The estimate for compound 3 lay 11 percentage points above the measured number; low and high end bracket the measured number.
By their numbers in this assay, from the lowest: compound 3; then compounds 2 and 1 (each within the scatter of the next).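

With only compound 1 and compound 2 in hand, the group on the sulfonyl sulfur looked freely exchangeable in this assay, but furan-3-yl in place of thiophen-2-yl gives a number 14 percentage points lower from compound 2 to compound 3 (beyond the scatter) and furan-3-yl in place of 3-fluorophenyl gives a number 17 percentage points lower from compound 1 to compound 3 (beyond the scatter) in the same read-out. Thiophen-2-yl and furan-3-yl match in heavy atoms, ring size and hydrogen-bond counts, so these counts do not separate two groups that the read-out does separate. Nothing measured here offers an explanation for the drop.

Furan-2-yl or thiophen-3-yl on the sulfonyl sulfur would tell the ring oxygen apart from the point of attachment, a question the compounds shown leave open. Also open, from the compounds shown here alone, is how a saturated ring such as tetrahydrofuran-3-yl would read at this position.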